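A few compounds are considered here, and "the series" means these few. Any claim that something is new, unique, unknown or untested is made for them only; others in the source may bear on it.

Measured so far in an ADME assay on HepG2 2.2.15 cells (Homo sapiens) for cytotoxicity, read by MTT assay, with stated times of 48 h and 9 days; on this read-out lower numbers stand for higher toxicity in this test and higher numbers for lower toxicity in this test:

Compound 1 `COc1ccc2c(=O)c(/C=C/C(=O)Nc3cccc(C)c3)coc2c1`: 554000 nM
Compound 2 `COc1ccc(CNC(=O)/C=C/c2coc3cc(O)ccc3c2=O)cc1`: 718000 nM
Compound 3 `COc1ccc2c(=O)c(/C=C/C(=O)Nc3ccccc3)coc2c1`: 523000 nM

Compound 3 sits at the low end of the three numbers, but its gaps to the others are not meaningful: compound 1 is nearest and compound 2 furthest, and both gaps fall within the scatter. Among the measured compounds shown here, the only single-point step among the measured compounds is a 1.1-fold lower number from compound 1 to compound 3 (0.03 log units; within the scatter), a hydrogen in place of a methyl on an aromatic carbon of the anilide ring, and it did not move the number beyond the scatter.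

Compound 4 `COc1cccc(NC(=O)/C=C/c2coc3cc(OC)ccc3c2=O)c1` differs from compound 3 by methoxy in place of hydrogen on an aromatic carbon. This is a small substituent swap on the same anilide ring as the step from compound 1 to compound 3, and that step gave no shift beyond the scatter. Compound 2, with a different amide and a free hydroxyl on the core, also stays within the scatter of the others. Nothing in the shared data points to a change beyond the scatter in this assay from adding a methoxy here.

The step from compound 3 to compound 4 is therefore estimated as a 1.0-fold lower number from compound 3 to compound 4 (0.00 log units; within the scatter). Compound 4 is expected at 520000 nM, within 260000 nM to 1040000 nM.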

Compound 4, half-maximal cytotoxic concentration: 1130000 nM
For compound 4 the middle estimate is 2.2-fold (0.34 log units) below the measured one; measured number above the stated range.
By their numbers in this assay, from the lowest: compounds 3, 1, 2 and 4 (each within the scatter of the next, the first and the last beyond it).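

In this assay, among the compounds shown here, the position meta to a large group on the aromatic ring of the amide proves responsive to substitution: phenyl to 3-methoxyphenyl gives a 2.2-fold higher number from compound 3 to compound 4 (0.33 log units; beyond the scatter) and is the first step to lie beyond the scatter. The change depends on the group, not merely on filling the position: a 1.1-fold lower number from compound 1 to compound 3 (0.03 log units; within the scatter) stays within the scatter, whereas a 2.0-fold higher number from compound 1 to compound 4 (0.31 log units; beyond the scatter) lies beyond it. The data offer no measured basis for explaining this difference.

Open, from the compounds shown here alone, is whether the shift is particular to methoxy or would also appear with an amine, a carboxylic acid or a longer alkoxy chain at this position. Also open, going by these compounds, is how methoxy behaves elsewhere on this ring, and compound 2 differs from the others in too many places to bear on either question.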